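The source may hold more compounds than are shown below. What is called first, only, known or untested is meant among the compounds shown, and "the series" means these compounds.

Series notes, compounds measured in an assay on isolated protein for antagonist activity at Bile acid receptor (Homo sapiens), read by TR-FRET, with a stated time of 20 min; on this read-out higher numbers stand for weaker inhibition and lower numbers for stronger inhibition:
compound 1, `Cc1ccc(-c2nn(-c3ccc(F)cc3)cc2C(=O)Nc2ccc(C)c(S(=O)(=O)N3CCOCC3)c2)cc1`, 24.3 nM
compound 2, `Cc1ccc(-c2nn(-c3ccc(Cl)cc3Cl)cc2C(=O)Nc2ccc(C)c(S(=O)(=O)N3CCOCC3)c2)cc1`, 14.1 nM
compound 3, `Cc1ccc(-c2nn(C(C)C)cc2C(=O)Nc2ccc(C)c(S(=O)(=O)N3CCOCC3)c2)cc1`, 49.1 nM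

Compound 3 stands at the highest number of the three; its nearest neighbour is compound 1 and its furthest is compound 2. Going by the values given here, the steps that bear on the present question are a 2.0-fold higher number from compound 1 to compound 3 (0.31 log units; beyond the scatter) and a 3.5-fold higher number from compound 2 to compound 3 (0.54 log units; beyond the scatter), both beyond the scatter, while a 1.7-fold lower number from compound 1 to compound 2 (0.24 log units; within the scatter) lies within it. Compound 4, `Cc1ccc(-c2nn(Cc3ccc4ccccc4c3)cc2C(=O)Nc2ccc(C)c(S(=O)(=O)N3CCOCC3)c2)cc1`, is not yet measured. It differs from compound 3 in one place: (naphthalen-2-yl)methyl in place of isopropyl on an aromatic nitrogen. The measured steps show that isopropyl on the aromatic nitrogen gives higher numbers than either 4-fluorophenyl or 2,4-dichlorophenyl in this assay. A (naphthalen-2-yl)methyl group is not directly covered by any measured pair, so the direction is taken from those two steps and the size kept modest. The step expected is a 2.5-fold lower number from compound 3 to compound 4 (0.39 log units; beyond the scatter). Compound 4 is therefore estimated at 20 nM, with a range of 7 nM to 60 nM.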

Compound 4, half-maximal inhibitory concentration: 10.2 nM
Estimate against measurement, compound 4: 2.0-fold (0.29 log units) above; low and high end bracket the measured number.
By their numbers in this assay, from the lowest: compounds 4, 2 and 1 (each within the scatter of the next, the first and the last beyond it); then compound 3.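

In this assay, (naphthalen-2-yl)methyl in place of isopropyl on the aromatic nitrogen gives a 4.8-fold lower number from compound 3 to compound 4 (0.68 log units; beyond the scatter) and shows that this position accepts a group of 11 heavy atoms with 2 six-membered aromatic rings of carbon only. Set against 4-fluorophenyl, the same group gives a 2.4-fold lower number from compound 1 to compound 4 (0.38 log units; beyond the scatter) and stands apart from it, whereas set against 2,4-dichlorophenyl it gives a 1.4-fold lower number from compound 2 to compound 4 (0.14 log units; within the scatter) and cannot be separated from it. Nothing on hand accounts for these steps.

The compounds shown do not separate the contribution of the methylene link from that of the second aromatic ring, which a plain benzyl group or a 2-naphthyl group on the same nitrogen would address. Going by these compounds, how an amine or a carboxylic acid carried on this group would read also remains open.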